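Notes on compound 4: fluoro in place of vinyl

The source may report more compounds than this note shows. Statements on the series, on what has been measured and on what is new or still open speak of the compounds shown alone.

Measured so far in a functional assay (muscle tissue) with Cavia porcellus as the target; on this read-out lower numbers stand for an effect already at smaller amounts and higher numbers for an effect only at larger amounts of compound:
compound 1 `C=Cc1ccccc1C1C(C(=O)OC)=C(C)N=C(C)/C1=C(\O)OC` gives 4.47 nM
compound 2 `COC(=O)C1=C(C)N=C(C)/C(=C(\O)OC)C1c1ccccc1I` gives 46.8 nM
compound 3 `COC(=O)C1=C(C)N=C(C)/C(=C(\O)OC)C1c1cccc(C)c1` gives 110 nM

Compound 1 stands lowest of the three numbers; the nearest step away from it is a 10-fold higher number from compound 1 to compound 2 (1.02 log units; beyond the scatter), the furthest a 25-fold higher number from compound 1 to compound 3 (1.39 log units; beyond the scatter). Compound 4 `COC(=O)C1=C(C)N=C(C)/C(=C(\O)OC)C1c1ccccc1F` differs from compound 1 in one place: fluoro in place of vinyl on an aromatic carbon. The step that bears on this is a 10-fold higher number from compound 1 to compound 2 (1.02 log units; beyond the scatter), where another group took the place of the vinyl on the same aromatic carbon; the further step a 2.4-fold higher number from compound 2 to compound 3 (0.37 log units; beyond the scatter) is smaller. A rise beyond the scatter in this assay is therefore expected for compound 4, estimated at 30 nM (range 8 nM to 120 nM), which means a 6.7-fold higher number from compound 1 to compound 4 (0.83 log units; beyond the scatter).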

Compound 4, half-maximal effective concentration: 42.7 nM
Beside the measured number, compound 4's estimate is 1.4-fold (0.15 log units) below it, within the range that was stated.
By their numbers in this assay, from the lowest: compound 1; then compounds 4 and 2 (each within the scatter of the next); then compound 3.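

In this assay, fluoro in place of vinyl gives a 9.6-fold higher number from compound 1 to compound 4 (0.98 log units; beyond the scatter), so on this aromatic carbon a small halogen falls short of vinyl just as iodo does. Fluoro in place of iodo gives a 1.1-fold lower number from compound 2 to compound 4 (0.04 log units; within the scatter), so these two halogens are not separated here, while 2-fluorophenyl in place of 3-methylphenyl gives a 2.6-fold lower number from compound 3 to compound 4 (0.41 log units; beyond the scatter). No available evidence accounts for these steps.

Still open, going by these compounds, is whether any other group on this aromatic carbon, such as ethyl, ethynyl or methoxy, matches vinyl. Also open, on these data alone, is whether chloro or bromo falls with fluoro and iodo.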